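Four-Membered Ring in Place of a Chain on the Carbonyl

The compounds below may be only part of what the source reports. "The series", "measured", "known", "first", "only" and "open" are said of these compounds alone.

Measured so far:
compound 1 `Cc1nc(S(C)(=O)=O)ccc1Oc1ncnc(OC2CCN(C(=O)O[C@H](C)CF)CC2)c1F` gives 79%
compound 2 `Cc1nc(S(C)(=O)=O)ccc1Oc1ncnc(OC2CCN(C(=O)SC(C)C)CC2)c1F` gives 81%
compound 3 `Cc1nc(S(C)(=O)=O)ccc1Oc1ncnc(OC2CCN(C(=S)OC(C)C)CC2)c1F` gives 47%

In a functional assay on isolated protein for inhibition of Glucose-dependent insulinotropic receptor (Rattus norvegicus), read by HTRF and cAMP accumulation (on this read-out lower numbers stand for smaller maximal responses and higher numbers for larger maximal responses), compound 1 stands second highest of the three numbers. Its nearest neighbour is compound 2 : a number 2 percentage points higher from compound 1 to compound 2 (within the scatter). Its furthest is compound 3 : a number 32 percentage points lower from compound 1 to compound 3 (beyond the scatter). Between the other two the step is a number 34 percentage points lower from compound 2 to compound 3 (beyond the scatter).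

Compound 4 `Cc1nc(S(C)(=O)=O)ccc1Oc1ncnc(OC2CCN(C(=O)C3(F)CCC3)CC2)c1F` has not yet been measured. It differs from compound 1 in one place: a group of 5 heavy atoms (4 carbon, 1 fluorine; one four-membered non-aromatic ring of carbon only) in place of a group of 5 heavy atoms (3 carbon, 1 oxygen, 1 fluorine; no ring), on a carbonyl carbon. The carbonyl itself is kept.

Within the data shown here, only one measured step changes a group on that same carbonyl carbon, and it stayed within the scatter: a number 2 percentage points higher from compound 1 to compound 2 (within the scatter). The two large steps, those leading to compound 3, change the group on the amine nitrogen in the ring and not the group on the carbonyl carbon, so they bear less on this change. The chemist therefore expects no step beyond the scatter in this assay. For compound 4 the expected step is a number 1 percentage points lower from compound 1 to compound 4 (within the scatter). The estimate for compound 4 is 78%, with a range from 62% to 92%.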

Compound 4, largest response reached (reported as efficacy), in percent of the reference or control that the assay uses: 91%
Estimate against measurement, compound 4: 13 percentage points below, and the stated range covers the measured number.
By their numbers in this assay, from the lowest: compound 3; then compounds 1, 2 and 4 (each within the scatter of the next, the first and the last beyond it).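

In this assay the carbonyl carbon now shows a change beyond the scatter, where the earlier change at this place did not: the group with the four-membered non-aromatic ring of carbon only, replacing the open chain with its oxygen, fluorine and defined stereocentre, gives a number 12 percentage points higher from compound 1 to compound 4 (beyond the scatter) and shows that a ring is accepted here without loss of response. The same ring cannot be told apart from the sulfur-linked chain of compound 2, since the comparison gives a number 10 percentage points higher from compound 2 to compound 4 (within the scatter) and so the chain with sulfur and the ring stand level at this place. The step of a number 44 percentage points higher from compound 3 to compound 4 (beyond the scatter) is the widest among these compounds, and nothing at hand explains this step or the others.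

As far as these compounds go, what a cyclobutyl group without the fluorine would give on the same carbonyl carbon stays open, so the share of the ring and the share of the fluorine remain unseparated. Also open, from the compounds shown here alone, is whether a cyclopropyl ring, a cyclopentyl ring or an amine on that carbonyl carbon would hold the response at this level.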